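Swapping cyclohexyl for isobutyl on the amine nitrogen

The source may report more compounds than this note shows. Statements on the series, on what has been measured and on what is new or still open speak of the compounds shown alone.

- Compound 1 `COc1cc(/C=C/C(=O)/C=C(/C=C/c2ccc(OC(C)=O)c(OC)c2)NC2CCCCC2)ccc1OC(C)=O`: 4400 nM
- Compound 2 `CC(C)CNC(=C\C(=O)/C=C/c1ccc(O)cc1)/C=C/c1ccc(O)cc1`: 18500 nM

Both values come from a functional assay on Caco-2 cells (Homo sapiens) for inhibition, read by sulforhodamine B assay, with a stated time of 72 h; a higher number here means a weaker inhibitor, a lower number a stronger inhibitor. Compound 1 holds the lower of the two numbers, and compound 2 lies beyond the scatter above it, so compound 1 is the stronger inhibitor of this pair.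

Compound 3 `COc1cc(/C=C/C(=O)/C=C(/C=C/c2ccc(OC(C)=O)c(OC)c2)NCC(C)C)ccc1OC(C)=O` is still unmeasured. It carries isobutyl in place of cyclohexyl on an amine nitrogen. Among the measured compounds shown here, no measured pair isolates this change, so its size in this assay cannot be read from the data. No step beyond the scatter is expected, with a slight lean towards a higher number. The expected move is a 1.5-fold higher number from compound 1 to compound 3 (0.17 log units; within the scatter). For compound 3 the estimated value is 6500 nM, with an expected range of 2800 nM to 15000 nM.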

Compound 3, half-maximal inhibitory concentration: > 25000 nM
Compound 3: no number, only a limit; the forecaster's own chance of this, stated with the estimate: 5%; middle value at least 3.8-fold (0.58 log units) from the limit.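

In this assay, with the core of compound 1 held fixed, isobutyl in place of cyclohexyl on the amine nitrogen is now isolated as a single change, and it weakens inhibition: the change gives an at least 5.6-fold higher number from compound 1 to compound 3 (0.75 log units; beyond the scatter). Compound 3 gives > 25000 nM, which is a limit of the assay and not a number. This position is therefore sensitive to the group it carries, at least for this pair, but the step can be given only as a minimum: the limit of > 25000 nM in this assay, at which 1 of the 3 values shown sits.

Cyclohexyl and isobutyl differ in both ring and carbon count, and the compounds shown do not tell which of these matters. A cyclobutyl or an n-butyl group on the same amine nitrogen would separate the two readings.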